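The source may report more compounds than this note shows. Statements on the series, on what has been measured and on what is new or still open speak of the compounds shown alone.

Measured so far in a functional assay on BT-549 cells (Homo sapiens) for inhibition, read by sulforhodamine B assay, with a stated time of 48 h; a lower number here means that less compound is tolerated, a higher number that more compound is tolerated:

Compound 1 `COc1cc(C)cc(-c2c(-c3ccnc(-c4ccc(N(C)C)cc4)c3)cnn2CC#N)c1`: > 100000 nM; this reading for compound 1 is a limit of this assay, not a number.
Compound 2 `COc1cc(C)cc(-c2nn(CC#N)cc2-c2ccnc(-c3ccc(N(C)C)cc3)c2)c1`: > 100000 nM; this reading for compound 2 is likewise a limit, not a number.
Compound 3 `COc1cc(C)cc(-c2nn(CC#N)cc2-c2ccc(-c3cccc(C(C)=O)c3)nc2)c1`: > 100000 nM; this reading for compound 3 is also a limit, not a number.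

Compound 2 therefore stands nowhere in particular among the numbers shown: its value in this assay is a limit only, and the two other values shown are limits as well. Among the measured compounds shown here, the whole picture so far is the limit of > 100000 nM in this assay, at which 3 of the 3 values shown sit, so no step between measured compounds can be sized, and no compound can be set above or below another.

The next compound, compound 4 `Cc1cc(O)cc(-c2nn(CC#N)cc2-c2ccnc(-c3ccc(N(C)C)cc3)c2)c1`, differs from compound 2 in one place: hydrogen in place of methyl on an oxygen on an aromatic ring. Nothing measured in the series speaks to this change, since every measurement so far sits at the same limit.

Given (the limit of > 100000 nM in this assay, at which 3 of the 3 values shown sit), the step from compound 2 to compound 4 is expected to be none beyond the scatter, that is a step that the limit leaves unreadable from compound 2 to compound 4, with the most likely outcome again a limit rather than a number. For compound 4 the estimate in this assay is 200000 nM, within 60000 nM to 1000000 nM.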

Compound 4, concentration lethal to 50% of the cells: > 100000 nM
Compound 4: only a limit was reported; the forecaster's own chance of this, stated with the estimate: 80%; the middle value is on the limit's open side.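

In this assay compound 4 gives > 100000 nM, which is a limit and not a number. No step from compound 2 to compound 4 can be read: the limit of > 100000 nM in this assay, at which 4 of the 4 values shown sit.

The compounds shown leave open what methoxy to hydroxy does in this assay, and whether any compound of the series reaches a measurable value there.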